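Replacing 6-chloropyridin-2-yl with 3-chlorophenyl

This account rests on a few compounds, and the source may have more. Where it says the series, first, only, none or still open, it means among the compounds named here.

Values measured in an ADME assay on PBMC cells (Homo sapiens) for cytotoxicity (on this read-out higher numbers stand for lower toxicity in this test and lower numbers for higher toxicity in this test), so far:
- compound 1 `CC(CCNC(=O)c1c(Cl)cncc1Cl)N1CCC(C(Oc2cccc(C#N)n2)c2ccc(C(F)(F)F)cc2)CC1` gives 15700 nM
- compound 2 `CC(CCNC(=O)c1c(Cl)cncc1Cl)N1CCC(C(Oc2cccc(C(=O)O)n2)c2ccc(C(F)(F)F)cc2)CC1` gives 28700 nM
- compound 3 `CC(CCNC(=O)c1c(Cl)cncc1Cl)N1CCC(C(Oc2cccc(Cl)n2)c2ccc(C(F)(F)F)cc2)CC1` gives > 32500 nM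

In this assay compound 3 stands at > 32500 nM as a limit and not a number. Compound 4 `CC(CCNC(=O)c1c(Cl)cncc1Cl)N1CCC(C(Oc2cccc(Cl)c2)c2ccc(C(F)(F)F)cc2)CC1` carries 3-chlorophenyl in place of 6-chloropyridin-2-yl on an oxygen on a saturated carbon and so has 3-chlorophenyl in place of 6-chloropyridin-2-yl on an oxygen on a saturated carbon. Among the compounds with values here, no measured step makes this change. The nearest steps alter only the other group on that ring: a 1.8-fold higher number from compound 1 to compound 2 (0.26 log units; within the scatter) and an at least 2.0-fold higher number from compound 1 to compound 3 (0.31 log units; beyond the scatter) and an at least 1.1-fold higher number from compound 2 to compound 3 (0.05 log units; that floor lies within the scatter) are all small. For compound 4 the expected step is an at least 1.3-fold lower number from compound 3 to compound 4 (0.13 log units; that floor lies within the scatter) and it is not expected to pass the scatter. For compound 4 24000 nM is the estimate, expected to fall within 11000 nM to 32500 nM on measurement.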

Compound 4, half-maximal cytotoxic concentration: 8100 nM
Beside the measured number, compound 4's estimate is 3.0-fold (0.47 log units) above it; measured number below the stated range.
By their numbers in this assay, from the lowest: compounds 4, 1 and 2 (each within the scatter of the next, the first and the last beyond it). At a limit, above all of these: compound 3.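

In this assay, within the data shown here, this is the first change to the ring itself rather than to the other group on it, and it gives an at least 4.0-fold lower number from compound 3 to compound 4 (0.60 log units; beyond the scatter). That step is only a floor, since compound 3 stands at a limit: the limit of > 32500 nM in this assay, at which 1 of the 4 values shown sits. Measured from the other two pyridines, the change gives a 3.5-fold lower number from compound 2 to compound 4 (0.55 log units; beyond the scatter) and a 1.9-fold lower number from compound 1 to compound 4 (0.29 log units; within the scatter), so its size depends on the starting group.

As far as these compounds go, the true value of compound 3 remains open. So does how a phenyl ring carrying a nitrile, a carboxylic acid or an amine would read.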